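Chloro to trifluoromethyl on the outer phenyl of compound 1

The compounds below may be only part of what the source reports. "The series", "measured", "known", "first", "only" and "open" are said of these compounds alone.

Compound 1 `O=C(Nc1cccc(-n2cc(-c3ccncc3)c(-c3ccc(Cl)c(O)c3)n2)c1)Nc1ccc(Cl)c(Cl)c1` gives 1090 nM in a functional assay on SNB-75 cells (Homo sapiens) for inhibition, read by sulforhodamine B assay, with a stated time of 48 h; on this read-out lower numbers stand for stronger inhibition of growth and higher numbers for weaker inhibition of growth.
Compound 2 `COc1cc(-c2nn(-c3cccc(NC(=O)c4cccc(C(F)(F)F)c4)c3)cc2-c2ccncc2)ccc1Cl` gives 1130 nM in this assay.
Compound 3 `COc1cc(-c2nn(-c3cccc(NC(=O)Nc4cccc(C(F)(F)F)c4)c3)cc2-c2ccncc2)ccc1Cl` gives 1160 nM in this assay.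

Compound 1 has the lowest of the three numbers, yet its gaps to compound 2 and to compound 3 are within the scatter, so the three stand level. Compound 4 `O=C(Nc1cccc(-n2cc(-c3ccncc3)c(-c3ccc(Cl)c(O)c3)n2)c1)Nc1ccc(Cl)c(C(F)(F)F)c1` differs from compound 1 in one place: trifluoromethyl in place of chloro on an aromatic carbon. Going by the values given here, the one measured step, a 1.0-fold higher number from compound 2 to compound 3 (0.01 log units; within the scatter), concerns a change at the carbonyl and not this swap, so no measured pair speaks to chloro against trifluoromethyl here. With nothing to point either way, compound 4 is expected to sit close to compound 1, with a step of a 1.0-fold higher number from compound 1 to compound 4 (0.00 log units; within the scatter) expected. For compound 4 the estimate is 1100 nM, with a range from 450 nM to 2700 nM.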

Compound 4, concentration for 50% growth inhibition: 678 nM
For compound 4 the middle estimate is 1.6-fold (0.21 log units) above the measured one; low and high end bracket the measured number.
By their numbers in this assay, from the lowest: compounds 4, 1, 2 and 3 (each within the scatter of the next).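

The earlier compounds shown here held no pair for this swap; at this position on the outer phenyl, trifluoromethyl in place of chloro gives a 1.6-fold lower number from compound 1 to compound 4 (0.21 log units; within the scatter) in this assay. A group of 4 heavy atoms thus stands level with one of 1 heavy atom on this aromatic carbon, with the chloro group in the place printed for it retained. No measurement offered here accounts for the result.

Open, going by these compounds, is whether a carboxylic acid or an amine on the same carbon would stay level with compound 1.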